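Fluoro for Carbamoyl on a Weak Growth Inhibitor

A few compounds are considered here, and "the series" means these few. Any claim that something is new, unique, unknown or untested is made for them only; others in the source may bear on it.

Compound 1 `CCC1C(=O)N(C)c2cnc(-n3ccc4cc(C(N)=O)ccc43)nc2N1c1ccn(C)n1` was tested in a functional assay on K562 cells (Homo sapiens) for antiproliferative activity, read by CCK-8 assay, with a stated time of 72 h (on this read-out higher numbers stand for weaker inhibition of growth and lower numbers for stronger inhibition of growth), where compound 1 gives 31300 nM. Of the two compounds with a number, this is the higher one, standing for the weaker inhibition of growth. Compound 2 `CC[C@@H]1C(=O)N(C)c2cnc(Nc3ccc(S(N)(=O)=O)cc3)nc2N1C1CCCC1` differs from compound 1 in several places; in this assay compound 2 gives 470 nM, a value well below that of compound 1 and beyond the scatter. Compound 3 `CCC1C(=O)N(C)c2cnc(Nc3ccc(S(=O)(=O)NCCO)cc3)nc2N1c1ccn(C)n1` was reported as "not active" (no number reported), without a number. Compound 4 `CCC1C(=O)N(C)c2cnc(-n3ccc4cc(F)ccc43)nc2N1c1ccn(C)n1` differs from compound 1 in one place: fluoro in place of carbamoyl on an aromatic carbon. For the measured compounds named here, no measured pair shows this change, so only an expectation can be given: a small weakening, close to the scatter, is expected, a 1.4-fold higher number from compound 1 to compound 4 (0.16 log units; within the scatter). Compound 4 is therefore expected near 45000 nM, within a range from 12000 nM to 150000 nM.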

Compound 4, concentration for 50% growth inhibition: 6070 nM
Beside the measured number, compound 4's estimate is 7.4-fold (0.87 log units) above it; the measured number lies below the stated range.
By their numbers in this assay, from the lowest: compound 2; then compound 4; then compound 1.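

This position on the six-membered aromatic ring responds clearly to the group it carries: in this assay, putting fluoro in place of carbamoyl gives a 5.2-fold lower number from compound 1 to compound 4 (0.71 log units; beyond the scatter), which stands for stronger inhibition of growth. So a single fluorine here, with no hydrogen-bond donor or acceptor, does better than the larger carbamoyl. Nothing measured here explains this difference. Still open, going by these compounds, is whether the step comes from losing carbamoyl or from gaining fluoro. Plain hydrogen, chlorine or an amine at this same place could help separate the two.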